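The source may report more compounds than this note shows. Statements on the series, on what has been measured and on what is new or still open speak of the compounds shown alone.

Compound 1 `COc1nn2cc(-c3cc4ccccc4o3)nc2s1` is the reference point of this small set. In an ADME assay on microsomes from liver (Rattus norvegicus) for metabolic stability, with a stated time of 10 min (a lower number here means that less of the compound is left, a higher number that more of the compound is left), compound 1 gives 31%, the highest of the three numbers measured. Compound 2 `Cc1nn2cc(-c3cc4ccccc4o3)nc2s1` gives 4% in this assay, and compound 3 `COc1nn2cc(-c3cc4cccc(OC)c4o3)nc2s1` gives 11%. The step from compound 1 to compound 2, methyl in place of methoxy on an aromatic carbon, is a number 27 percentage points lower from compound 1 to compound 2 (beyond the scatter); the step from compound 1 to compound 3, methoxy in place of hydrogen on an aromatic carbon, is a number 20 percentage points lower from compound 1 to compound 3 (beyond the scatter).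

Compound 4 `COc1ccc2oc(-c3cn4nc(OC)sc4n3)cc2c1` has not been measured in this assay. It differs from compound 1 as follows: methoxy in place of hydrogen on an aromatic carbon. For the measured compounds named here, the change is of the same kind as the one leading to compound 3, only at a different aromatic carbon of the shared core, so the step from compound 1 to compound 3 is the one that bears on it. That step was a modest fall beyond the scatter. Compound 4 is therefore expected to come in lower than compound 1 by a step of a number 17 percentage points lower from compound 1 to compound 4 (beyond the scatter). The estimate for compound 4 is 14%, within a range from 4% to 28%.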

Compound 4, percent of the compound remaining: 38%
Compound 4: the middle estimate sits 24 percentage points below what was measured; measured number outside the range, above it.
By their numbers in this assay, from the lowest: compounds 2 and 3 (each within the scatter of the next); then compounds 1 and 4 (each within the scatter of the next).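

Placed on this carbon of the six-membered aromatic ring, para to a fused ring, methoxy in place of hydrogen does not have the cost seen earlier in this assay: the result is a number 7 percentage points higher from compound 1 to compound 4 (within the scatter) and so gives no real change. The same exchange at another aromatic carbon of the shared core gave a number 20 percentage points lower from compound 1 to compound 3 (beyond the scatter), so the two steps show that the outcome of adding methoxy depends on where on this ring it sits, and that this position tolerates it. Nothing at hand explains the difference between the two positions.

On these data alone, it remains open whether a longer chain such as ethoxy, or an amine, would be tolerated on this same carbon. The compounds shown also leave open how methoxy behaves at the other carbons of this ring.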